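This account rests on a few compounds, and the source may have more. Where it says the series, first, only, none or still open, it means among the compounds named here.

Compound 1, `O=C1/C(=C/c2ccccc2F)CN(C(=S)SCc2cn(Cc3cccc(Cl)c3)nn2)C/C1=C\c1ccccc1F`: in a functional assay on 4T1 cells (Mus musculus) for cytotoxicity, read by MTT assay, with a stated time of 24 h (a higher number here means a weaker inhibitor, a lower number a stronger inhibitor), compound 1 reaches only the limit of the assay, (the limit of > 100000 nM in this assay, at which 1 of the 3 values shown sits), and its entry of > 100000 nM is a limit rather than a number.
Compound 2, `Cc1ccc(/C=C2\CN(C(=S)SCc3cn(Cc4ccccc4Cl)nn3)C/C(=C\c3ccc(C)cc3)C2=O)cc1`: in this assay compound 2 gives 49300 nM.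
Compound 3, `Cc1ccc(/C=C2\CN(Cc3cn(Cc4ccccc4Cl)nn3)C/C(=C\c3ccc(C)cc3)C2=O)cc1`: in this assay compound 3 gives 23200 nM.

Of the two numbers measured, compound 3 has the lower one, and the gap to compound 2 lies beyond the usual scatter; compound 1 contributes only a limit. No two of these compounds differ in a single place, so no single step in this assay has yet been isolated, and compound 2 and compound 1 each differ from compound 3 at more than one point.

Compound 4, `Cc1ccc(/C=C2\CN(Cc3cn(Cc4ccc(F)cc4)nn3)C/C(=C\c3ccc(C)cc3)C2=O)cc1`, is the next compound to be measured. It differs from compound 3 in one place: 4-fluorophenyl in place of 2-chlorophenyl on a saturated chain carbon bound to an aromatic nitrogen. Among the measured compounds shown here, the study holds no earlier example of this exchange, so nothing measured points one way or the other. The expectation is a step from compound 3 to compound 4 of a 1.3-fold higher number from compound 3 to compound 4 (0.11 log units; within the scatter), within the scatter rather than beyond it. For compound 4 the estimate in this assay is 30000 nM, with a range from 12000 nM to 75000 nM.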

Compound 4, half-maximal inhibitory concentration: 57200 nM
Compound 4: the middle estimate sits 1.9-fold (0.28 log units) below what was measured, and the stated range covers the measured number.
By their numbers in this assay, from the lowest: compound 3; then compounds 2 and 4 (each within the scatter of the next). At a limit, above all of these: compound 1.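

In this assay, among the compounds shown here, placing 4-fluorophenyl where 2-chlorophenyl stood, on a saturated chain carbon bound to an aromatic nitrogen, gives a 2.5-fold higher number from compound 3 to compound 4 (0.39 log units; beyond the scatter), the first single change that can be read on its own. It shows that this position is sensitive to the aryl group it carries, with the 2-chlorophenyl group giving the stronger inhibitor of this pair. Nothing measured here explains the size or direction of this step.

The exchange alters both the halogen and its place on the ring, and the compounds shown do not separate these two changes. A 4-chlorophenyl or 2-fluorophenyl group at this position would tell them apart, and an unsubstituted phenyl group would show what either halogen contributes.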